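The source may hold more compounds than are shown below. What is called first, only, known or untested is meant among the compounds shown, and "the series" means these compounds.

Measured compounds:
compound 1, `Cc1c(C2CC2)nc2cnc(-n3ccc(OCc4ccc(Cl)cc4)cc3=O)cn12`, 44 nM in an assay on CHO cells for displacement of a labelled ligand from melanin-concentrating hormone receptor 1 (Homo sapiens), read by scintillation counting, with a stated time of 1 h; a lower number here means a stronger inhibitor, a higher number a weaker inhibitor
compound 2, `Cc1c(C2CC2)nc2ncc(-n3ccc(OCc4ccc(Cl)cc4)cc3=O)cn12`, > 1000 nM in this assay
compound 3, `Cc1nc2ccc(-n3ccc(OCc4ccc(F)cc4)cc3=O)cc2n1C`, 77 nM in this assay

Of the two compounds that give a number in this assay, compound 3 has the higher one, and compound 1 is its nearest neighbour, a gap that lies within the scatter. The value of compound 2 is a limit of the assay and not a number: the limit of > 1000 nM in this assay, at which 1 of the 3 values shown sits.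

Compound 4, `Cn1c(C2CC2)nc2ccc(-n3ccc(OCc4ccc(F)cc4)cc3=O)cc21`, differs from compound 3 in one place: cyclopropyl in place of methyl on an aromatic carbon. Going by the values given here, no measured pair in this set shows this exchange on its own, so its size is not known from the data. Among the compounds with values here, compound 1, which carries cyclopropyl on its own core and gives 44 nM, and compound 3, which carries methyl and gives 77 nM, sit within the scatter of each other, but they differ in more than that one group, so they give no clean step. Compound 4 is therefore expected to land close to compound 3, at 60 nM, within a range from 20 nM to 200 nM. The expected step of a 1.3-fold lower number from compound 3 to compound 4 (0.11 log units; within the scatter) is estimated to be small, in no clear direction, and not beyond the scatter.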

Compound 4, half-maximal inhibitory concentration: 40 nM
Estimate against measurement, compound 4: 1.5-fold (0.18 log units) above; the range from low to high includes it.
By their numbers in this assay, from the lowest: compounds 4, 1 and 3 (each within the scatter of the next). At a limit, above all of these: compound 2.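

On the aromatic carbon between two ring nitrogen atoms, cyclopropyl in place of methyl gives, in this assay, a 1.9-fold lower number from compound 3 to compound 4 (0.28 log units; within the scatter), so a three-membered ring of 3 heavy atoms and a single methyl carbon cannot be told apart at this position on this core. Going by these compounds alone, this is the first pair in the set in which the exchange stands on its own, and it shows that this position accepts either group with no change beyond the scatter, something the earlier compounds could not show because they differ in more than one place. Nothing shown here bears on why the two groups give such similar values.

As far as these compounds go, how far this tolerance extends remains open, since a longer chain such as butyl, a phenyl ring, an amine or a carboxylic acid on this same carbon could give a very different number. From the compounds shown here alone, it is also open whether methyl in place of cyclopropyl on the core of compound 1 would behave as this pair does.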